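The compounds below may be only part of what the source reports. "The series", "measured", "known", "first", "only" and "open" are said of these compounds alone.

Measured compounds:
compound 1, `COc1cccc(N2CCN(C(=O)C(C)N3C(=O)CCC3=O)CC2)c1`: 0%
compound 2, `CCC(C(=O)N1CCN(c2cccc(OC)c2)CC1)N1C(=O)CCC1=O`: 0%
compound 3, `CC(C(=O)N1CCN(c2ccc(C(F)(F)F)cc2)CC1)N1C(=O)CCC1=O`: 0%

In a functional assay on the whole organism (strain Swiss) with Mus musculus as the target, in the maximal electroshock model, with a stated time of 1 h, at a dose of 300 mg/kg by the intraperitoneal route (on this read-out higher numbers stand for a stronger effect at the one dose given and lower numbers for a weaker effect), compound 1 gives 0%. Compound 2 differs from compound 1 in one place, (methyl in place of hydrogen on a saturated chain carbon, two bonds along the chain from an amide-type nitrogen in a ring and a carbonyl carbon), and in this assay compound 2 gives 0%, so that no change at the digits printed from compound 1 to compound 2 (within the scatter). Compound 3 rests on a different core; how its core differs from that of compound 1 is not broken down here. In this assay compound 3 gives 0%, level with compound 1 and compound 2.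

Compound 4, `CCC(C(=O)N1CCN(c2ccc(C(F)(F)F)cc2)CC1)N1C(=O)CCC1=O`, has not yet been tested. Among the measured compounds shown here, it differs from compound 3 by methyl in place of hydrogen on a saturated chain carbon, two bonds along the chain from an amide-type nitrogen in a ring and a carbonyl carbon, which is the same change as the one from compound 1 to compound 2, at the same place. The step that is expected from compound 3 to compound 4 is no change at the digits printed from compound 3 to compound 4 (within the scatter), because the matching step no change at the digits printed from compound 1 to compound 2 (within the scatter) and because compound 3 itself gives 0%. Compound 4 is therefore estimated at 0% in this assay, with an expected range from 0% to 10%.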

Compound 4, a percentage reported as activity, at one dose (the size of the read-out at that dose, not a potency): 0%
For compound 4 middle estimate and measured number coincide at the digits printed; low and high end bracket the measured number.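

In this assay the methyl in place of hydrogen on the saturated chain carbon leaves the read-out as it was, with no change at the digits printed from compound 3 to compound 4 (within the scatter), and set beside the earlier step the change reads alike on both cores: the same change on two cores in this assay, no change at the digits printed (within the scatter) from compound 1 to compound 2 and no change at the digits printed (within the scatter) from compound 3 to compound 4, 0 percentage points apart, within the scatter of two such steps. This shows that, on these two cores, adding the methyl brings no measurable effect into this read-out at the one dose given. Among the compounds shown here, it does not show that the change transfers with a constant size, since all four compounds share the same value, with compound 4 at 0%, and no step starting from a measurable effect is available for comparison.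

The compounds shown leave open whether a longer chain such as propyl in place of the methyl would give any read-out in this assay. They also leave open what an amine or a carboxylic acid in place of the methoxy or trifluoromethyl group would give, and whether the methyl step would stay as small on such a core.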